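The compounds below may be only part of what the source reports. "The series", "measured", "known", "first", "only" and "open" are said of these compounds alone.

In a functional assay on SW620/5-FU cells (Homo sapiens) for cytotoxicity, read by MTT assay, with a stated time of 48 h, in the presence of a further agent that is not named here (on this read-out lower numbers stand for an effect already at smaller amounts and higher numbers for an effect only at larger amounts of compound), compound 1 `Cc1nn(C)c2nc(NNC(=O)Nc3cc(Cl)nc(Cl)c3)cc(-c3ccco3)c12` gives > 100000 nM, which is a limit of the assay and not a number. In this assay compound 2 `CCCc1cc(NNC(=O)Nc2cc(Cl)nc(Cl)c2)nc2c1c(C(F)(F)F)nn2C` gives a measured 11700 nM. Compound 3 `Cc1cc(NNC(=O)Nc2cc(Cl)nc(Cl)c2)nc2c1c(C)nn2C` differs from compound 1 by methyl in place of furan-2-yl on an aromatic carbon, opposite the ring nitrogen (methyl in place of furan-2-yl on an aromatic carbon). Going by the values given here, no measured step bears on this change, but compound 2, which also lacks furan-2-yl, reads 11700 nM, so a moderate move toward lower numbers in this assay is expected, the estimated step being an at least 3.3-fold lower number from compound 1 to compound 3 (0.52 log units; beyond the scatter). In this assay the estimate for compound 3 is 30000 nM, with an expected range of 8000 nM to 100000 nM.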

Compound 3, half-maximal effective concentration: > 100000 nM
Compound 3: only a limit was reported; the forecaster's own chance of this, stated with the estimate: 30%; at least 3.3-fold (0.52 log units) between middle value and limit.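

The step between compound 1 and compound 3 cannot be read in this assay, as both values are limits and not numbers: the limit of > 100000 nM in this assay, at which 2 of the 3 values shown sit.

As far as these compounds go, whether methyl in place of furan-2-yl changes the read-out at all remains open.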